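The compounds below may be only part of what the source reports. "The series", "measured", "known", "first", "only" and "open" are said of these compounds alone.

Measured compounds:
compound 1, `O=C(Nc1ccc(C(F)(F)F)cc1)c1cc(Cl)ccc1O`: 510 nM in a functional assay on HL-60 cells (Homo sapiens) for cytotoxicity, read by luminescence and CellTiter-Glo, with a stated time of 3 days; on this read-out higher numbers stand for weaker inhibition and lower numbers for stronger inhibition
compound 2, `O=C(Nc1ccc(C(F)(F)F)cc1)c1cc(Cl)c(-c2ccccc2)cc1O`: 490 nM in this assay
compound 3, `N#Cc1ccc(NC(=O)c2cc(Br)c(-c3ccccc3)cc2O)cc1`: 700 nM in this assay

Among the compounds with values here, all three numbers lie within the scatter of one another; compound 3 stands at the highest number, with compound 1 nearest to it, but no gap between any pair is beyond the scatter. Within the data shown here, the one single-place change that is measured runs from compound 2 to compound 1, (hydrogen in place of phenyl on an aromatic carbon), and gave a 1.0-fold higher number from compound 2 to compound 1 (0.02 log units; within the scatter). The difference between the core of compound 2 and the core of compound 3 is not broken down here.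

Compound 4, `N#Cc1ccc(NC(=O)c2cc(Br)ccc2O)cc1`, is not yet measured in this assay. It differs from compound 3 by hydrogen in place of phenyl on an aromatic carbon. This is the same kind of change as that from compound 2 to compound 1, not the same change: in compound 2 the place is ortho to a chloro group, in compound 3 it is ortho to a bromo group. In this assay a step of no change at the digits printed from compound 3 to compound 4 (within the scatter) is expected from compound 3 to compound 4, because the like change in the chloro series gave a 1.0-fold higher number from compound 2 to compound 1 (0.02 log units; within the scatter). Compound 4 is therefore estimated at 700 nM in this assay, with a range from 350 nM to 1400 nM.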

Compound 4, half-maximal inhibitory concentration: 620 nM
Compound 4: middle estimate off by 1.1-fold (0.05 log units), on the high side; measured number inside the range.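

In this assay, hydrogen in place of phenyl gave a 1.1-fold lower number from compound 3 to compound 4 (0.05 log units; within the scatter), so on this core too the step stays within the scatter. The same change on the two cores gives steps that cannot be told apart: the same change on two cores in this assay, a 1.0-fold higher number (0.02 log units; within the scatter) from compound 2 to compound 1 and a 1.1-fold lower number (0.05 log units; within the scatter) from compound 3 to compound 4, 1.2-fold (0.07 log units) apart, within the scatter of two such steps This supports carrying the change between these two cores only; it does not show that the result holds on any other core, and with both steps within the scatter, it gives no size for an effect of the change on either core.

The cores also differ in chloro against bromo and in trifluoromethyl against nitrile, and the compounds shown do not separate these two differences. Phenyl and hydrogen are the only groups shown at this place, so it remains open whether an amine, a carboxylic acid or a longer chain there would give a number beyond the scatter.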